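Exchanging the Aromatic Group on the Shared Core

The compounds below may be only part of what the source reports. "The series", "measured", "known", "first", "only" and "open" are said of these compounds alone.

In an ADME assay (liver) for metabolic stability, with Liver microsome (Homo sapiens) as the target, using microsomes and NADPH, with a stated time of 30 min, tested at 1 uM (on this read-out lower numbers stand for slow clearance and higher numbers for fast clearance), compound 1 `Cc1csc(-c2cc(C(O)(C(F)(F)F)C(F)(F)F)cnc2N2CCN(S(=O)(=O)c3ccc(N)nc3)CC2)c1` gives 29 mL.min-1.g-1 and compound 2 `Nc1ccc(S(=O)(=O)N2CCN(c3ncc(C(O)(C(F)(F)F)C(F)(F)F)cc3-c3ccccc3O)CC2)cn1` gives 22 mL.min-1.g-1, so compound 2 stands within the scatter of compound 1. Compound 3 `CS(=O)(=O)Nc1cccc(-c2cc(C(O)(C(F)(F)F)C(F)(F)F)cnc2N2CCN(S(=O)(=O)c3ccc(N)nc3)CC2)c1` carries 3-(methanesulfonamido)phenyl in place of 2-hydroxyphenyl on an aromatic carbon. Among the measured compounds shown here, the only measured step, a 1.3-fold lower number from compound 1 to compound 2 (0.12 log units; within the scatter), exchanges 4-methylthiophen-2-yl for 2-hydroxyphenyl and stays within the scatter, so no shift beyond the scatter is expected here, in either direction. The expected change is an estimated 1.1-fold higher number from compound 2 to compound 3 (0.04 log units; within the scatter). For compound 3 the estimated value is 24 mL.min-1.g-1, with an expected range of 11 mL.min-1.g-1 to 52 mL.min-1.g-1.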

Compound 3, intrinsic clearance in microsomes: 40 mL.min-1.g-1
Beside the measured number, compound 3's estimate is 1.7-fold (0.22 log units) below it; the range from low to high includes it.
By their numbers in this assay, from the lowest: compounds 2, 1 and 3 (each within the scatter of the next).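

At this aromatic carbon, ortho to a large group, 3-(methanesulfonamido)phenyl keeps this assay within the scatter of both earlier groups (a 1.8-fold higher number from compound 2 to compound 3 (0.26 log units; within the scatter)) and (a 1.4-fold higher number from compound 1 to compound 3 (0.14 log units; within the scatter)). The read-out thus does not separate 4-methylthiophen-2-yl, 2-hydroxyphenyl and 3-(methanesulfonamido)phenyl here, even with 11 heavy atoms entering where 7 leave. No supporting data on hand explain these values.

On these data alone, whether any group at this carbon moves clearance beyond the scatter stays open. An amine or a carboxylic acid on the phenyl ring would test this.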